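The source may report more compounds than this note shows. Statements on the series, on what has been measured and on what is new or still open speak of the compounds shown alone.

Within the data shown here, compound 1 `NC1=NC2(CCSCC2)N(OCCCOc2cccc(Cl)c2)C(N)=N1` is the only member of this small set with a number in hand. In an assay on isolated protein for inhibition of Dihydrofolate reductase (Homo sapiens), read by spectrophotometry, using NADPH, with stated times of 5 s and 6 min, tested at 50 uM (a lower number here means a weaker effect, a higher number a stronger effect of the compound at the concentration tested), compound 1 gives 88.8%, which places it at a strong level of effect at the concentration tested. Compound 2 `NC1=NC2(CCOCC2)N(OCCCOc2ccc(Cl)cc2Cl)C(N)=N1` carries no result in this assay and is recorded as "not determined" (no result reported). Compound 3 `NC1=NC2(CCOCC2)N(OCCCOc2ccc(Br)cc2)C(N)=N1` likewise stands in this assay as "not determined" (no result reported). Among the measured compounds shown here, with a single number, no step between measured compounds can be drawn, and compound 1 stands alone as the reference.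

Compound 4 `COc1ccc(OCCCON2C(N)=NC(N)=NC23CCSCC3)cc1` differs from compound 1 in one place: 4-methoxyphenyl in place of 3-chlorophenyl on an oxygen on a saturated carbon. Nothing measured here shows how this change acts, so any expectation rests on one anchor. That anchor is the value of compound 1, 88.8% in this assay. From there a modest fall, perhaps no larger than the scatter, is expected: a number 12.8 percentage points lower from compound 1 to compound 4 (beyond the scatter). Compound 4 is therefore expected to give about 76% in this assay, within a range from 52% to 92%.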

Compound 4, a percentage reported as inhibition, at one concentration (the size of the read-out at that concentration, not a potency): 86.6%
For compound 4 the middle estimate is 10.6 percentage points below the measured one, within the range that was stated.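

In this assay, replacing 3-chlorophenyl with 4-methoxyphenyl on an oxygen on a saturated carbon amounts to a number 2.2 percentage points lower from compound 1 to compound 4 (within the scatter), so this position accepts a second substituted phenyl group with no change that the assay can resolve. The chlorine-bearing group leaves and a group with a hydrogen-bond acceptor enters, yet the read-out does not separate the two compounds at the single concentration tested, and such a percentage is not a potency. Nothing available here bears on why the two compounds read alike.

The compounds shown leave open whether an amine or a carboxylic acid at this place would also keep the effect. They also leave open how a longer chain carrying the 4-methoxyphenyl group would read in this assay.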